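A few compounds are considered here, and "the series" means these few. Any claim that something is new, unique, unknown or untested is made for them only; others in the source may bear on it.

Measured so far in a functional assay on Mahlavu cells (Homo sapiens) for antiproliferative activity, read by sulforhodamine B assay, with a stated time of 72 h; on this read-out lower numbers stand for stronger inhibition and higher numbers for weaker inhibition:
compound 1 `FC(F)(F)c1ccc(CN2CCN(Cc3cc(-c4ccc(OCc5ccccc5)cc4)on3)CC2)cc1` gives 11700 nM;
compound 2 `Cc1cc(C)cc(COc2ccc(-c3cc(CN4CCN(Cc5ccc(C(F)(F)F)cc5)CC4)no3)cc2)c1` gives 6000 nM.

Of these two numbers compound 2 carries the smaller one, but the gap between them, a 2.0-fold lower number from compound 1 to compound 2 (0.29 log units; within the scatter), lies within the scatter, so the two compounds cannot be told apart on this evidence. Compound 3 `FC(F)(F)c1ccc(CN2CCN(Cc3cc(-c4ccc(OCc5cccc(Cl)c5)cc4)on3)CC2)cc1` has not yet been measured. It differs from compound 2 in one place: 3-chlorophenyl in place of 3,5-dimethylphenyl on a saturated chain carbon bound to an oxygen on an aromatic ring. Among the compounds with values here, only one measured step bears on such a change, the one that also swaps the ring on that same saturated chain carbon: a 2.0-fold lower number from compound 1 to compound 2 (0.29 log units; within the scatter), which stayed within the scatter. No movement beyond the scatter is therefore expected for compound 3 in this assay, and the expected step is a 1.3-fold higher number from compound 2 to compound 3 (0.12 log units; within the scatter). Compound 3 is estimated at 8000 nM, with a range from 3000 nM to 20000 nM.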

Compound 3, half-maximal inhibitory concentration: 4100 nM
Beside the measured number, compound 3's estimate is 2.0-fold (0.29 log units) above it; the range from low to high includes it.
By their numbers in this assay, from the lowest: compounds 3, 2 and 1 (each within the scatter of the next, the first and the last beyond it).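

In this assay, within the data shown here, the step of a 2.9-fold lower number from compound 1 to compound 3 (0.46 log units; beyond the scatter) is the first here to pass beyond the scatter: chloro in place of hydrogen on an aromatic carbon has a modest effect, so this ring can respond to a single substitution. Compound 2 does not clearly share that gain, as its step from compound 1 stayed within the scatter, and the exchange of 3,5-dimethylphenyl for 3-chlorophenyl, a 1.5-fold lower number from compound 2 to compound 3 (0.17 log units; within the scatter), leaves compound 2 and compound 3 indistinguishable. Nothing available here accounts for the effect of the chloro group.

Going by these compounds, it remains open whether a fluoro, bromo or methoxy group in place of the chloro would give a similar number. Also open, on these data alone, is whether a ring carrying an amine or a carboxylic acid would move the number further in either direction.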